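The compounds below may be only part of what the source reports. "The series", "measured", "known", "first", "only" and "open" are said of these compounds alone.

Compound 1, `COC(=O)C1=CN(C)C(=O)[C@@H]2C(CN3CCN(Cc4ccc(C(F)(F)F)cc4)CC3)=CC[C@H]12`: 72.2%
Compound 2, `COC(=O)C1=CN(C(C)C)C(=O)[C@@H]2C(CN3CCN(Cc4ccc([N+](=O)[O-])cc4)CC3)=CC[C@H]12`: 74.3%
Compound 3, `COC(=O)C1=CN(C(C)C)C(=O)[C@@H]2C(CN3CCN(Cc4ccc(C(F)(F)F)cc4)CC3)=CC[C@H]12`: 71.6%

All three were measured in a functional assay on Cortical neurone cells (Rattus norvegicus, strain Sprague-Dawley), read by MTT assay, with stated times of 24 h and 2 h, tested at 1 uM; on this read-out higher numbers stand for a stronger effect at the one concentration tested and lower numbers for a weaker effect. Compound 3 gives the smallest of the three numbers, but the differences to both neighbours are small: a number 0.6 percentage points lower from compound 1 to compound 3 (within the scatter) and a number 2.7 percentage points lower from compound 2 to compound 3 (within the scatter), so the three compounds are not separated from one another on this read-out.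

Compound 4, `COC(=O)C1=CN(C(C)C)C(=O)[C@@H]2C(CN3CCN(Cc4cccc(OC)c4)CC3)=CC[C@H]12`, has not been measured. It differs from compound 3 in one place: 3-methoxyphenyl in place of 4-(trifluoromethyl)phenyl on a saturated chain carbon bound to an amine nitrogen in a ring. Going by the values given here, of the two measured steps, only the one from compound 2 to compound 3 touches the same benzyl ring, and that exchange of one aromatic substituent for another moved the number by a number 2.7 percentage points lower from compound 2 to compound 3 (within the scatter), within the scatter. The other step, from compound 1 to compound 3, changed a different part of the molecule and was also within the scatter. Among the compounds with values here, with no step at this ring that reached beyond the scatter, the change to compound 4 is expected to leave the number in this assay where it was, with an expected step of a number 0.4 percentage points higher from compound 3 to compound 4 (within the scatter). Compound 4 is therefore estimated at 72%, in a range from 62% to 82%.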

Compound 4, a percentage reported as activity, at one concentration (the size of the read-out at that concentration, not a potency): 62.1%
For compound 4 the middle estimate is 9.9 percentage points above the measured one, and the stated range covers the measured number.
By their numbers in this assay, from the lowest: compounds 4, 3, 1 and 2 (each within the scatter of the next, the first and the last beyond it).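

At this position, on a saturated chain carbon bound to an amine nitrogen in a ring, this assay now shows a change that reaches beyond the scatter: 3-methoxyphenyl in place of 4-nitrophenyl gives a number 12.2 percentage points lower from compound 2 to compound 4 (beyond the scatter). Going by these compounds alone, the same group in place of 4-(trifluoromethyl)phenyl gives a number 9.5 percentage points lower from compound 3 to compound 4 (within the scatter), so the outcome of bringing in 3-methoxyphenyl depends on the group it replaces, and only one of the two exchanges separates the compounds. Nothing available explains this difference between the two steps.

The compounds shown leave open whether the methoxy group itself or its place on the ring goes with the lower number in compound 4. They also leave open where an unsubstituted phenyl or a ring carrying an amine would stand.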